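Dichlorobenzyl in place of benzyl on the hydroxamate side

The source may hold more compounds than are shown below. What is called first, only, known or untested is meant among the compounds shown, and "the series" means these compounds.

Compounds measured so far:
compound 1 `O=C(NOCc1ccc(Cl)cc1Cl)c1cn(-c2ccccc2)nc1-c1ccccc1` gives 5100 nM
compound 2 `COc1ccc(-c2nn(-c3ccccc3)cc2C(=O)NOCc2ccc(Cl)cc2Cl)cc1` gives 5750 nM
compound 3 `O=C(NOCc1ccccc1)c1cn(-c2ccccc2)nc1-c1ccc(Cl)cc1` gives 8350 nM

In a functional assay on HeLa cells (Homo sapiens) for antiproliferative activity, read by MTT assay, with a stated time of 48 h, in the presence of a further agent that is not named here (on this read-out lower numbers stand for stronger inhibition of growth and higher numbers for weaker inhibition of growth), the three numbers lie close together: the step of a 1.1-fold higher number from compound 1 to compound 2 (0.05 log units; within the scatter) is within the scatter, and compound 3, whose number is the largest of the three, is within the scatter of both compound 2 and compound 1. Compound 4 `O=C(NOCc1ccc(Cl)cc1Cl)c1cn(-c2ccccc2)nc1-c1ccc(Cl)cc1` differs from compound 3 by 2,4-dichlorophenyl in place of phenyl on a saturated chain carbon bound to an oxygen; in other words, benzyl to 2,4-dichlorobenzyl. Going by the values given here, no measured step covers exactly this change. Among the compounds with values here, compound 1 and compound 3 carry the two benzyl variants but also differ on the other phenyl, so their values show only that the pair lies within the scatter. With the shown numbers all within one band of one another, a step of the size a 1.5-fold lower number from compound 3 to compound 4 (0.18 log units; within the scatter) is expected in this assay, that is, none beyond the scatter. Compound 4 is therefore estimated at 5500 nM, in a range from 2500 nM to 12000 nM.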

Compound 4, concentration for 50% growth inhibition: 5160 nM
Estimate against measurement, compound 4: 1.1-fold (0.03 log units) above; the range from low to high includes it.
By their numbers in this assay, from the lowest: compounds 1, 4, 2 and 3 (each within the scatter of the next).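

In this assay the change from benzyl to 2,4-dichlorobenzyl can now be read directly, with the rest of the molecule held the same, and a 1.6-fold lower number from compound 3 to compound 4 (0.21 log units; within the scatter) shows that it stays within the scatter. With 2,4-dichlorobenzyl held on the hydroxamate side, a 1.1-fold lower number from compound 2 to compound 4 (0.05 log units; within the scatter) and a 1.0-fold higher number from compound 1 to compound 4 (0.01 log units; within the scatter) add chloro to the comparison on the aromatic carbon, so that hydrogen, methoxy and chloro there cannot be told apart in this read-out. No measurement given here accounts for why these numbers stay so close.

From the compounds shown here alone, this benzyl change is read on a single pair, so whether it holds with hydrogen or methoxy on the other phenyl remains open. Going by these compounds, it is also open whether an amine or a carboxylic acid on the benzyl group, or a longer chain in its place, would give a step beyond the scatter.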